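A Methoxy Removed at the Edge of Detection

The source may hold more compounds than are shown below. What is called first, only, known or untested is meant among the compounds shown, and "the series" means these compounds.

Of the compounds shown here, three of one shared core have been tested in a functional assay on K562 cells (Homo sapiens) for cytotoxicity, with a stated time of 72 h; on this read-out higher numbers stand for weaker inhibition and lower numbers for stronger inhibition. Compound 1, `CCc1cccc(-c2nn3c(c2-c2ccnc(Cl)c2)C(C)C(C)(C)C3)n1`, gives 82000 nM in this assay. Compound 2, `CC1(C)Cc2c(-c3ccncc3)c(-c3ccccn3)nn2C1`, reaches only the limit of this assay, > 100000 nM, and no number. Compound 3, `COCC1c2c(-c3ccncc3)c(-c3cccc(C)n3)nn2CC1(C)C`, likewise reaches only the limit, > 100000 nM. Compound 3 therefore stands at the weak end of what is shown, without a number of its own, and the same holds for the majority of the set: the limit of > 100000 nM in this assay, at which 2 of the 3 values shown sit.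

Compound 4, `Cc1cccc(-c2nn3c(c2-c2ccncc2)C(C)C(C)(C)C3)n1`, differs from compound 3 by a single change, (hydrogen in place of methoxy on a saturated chain carbon bound to a saturated ring carbon), which read one bond further out is methoxymethyl to methyl. No step between measured compounds is shown, so the size of this change cannot be read directly; compound 1, which also bears methyl rather than methoxymethyl, gives only a weak number. The step that the limit leaves unreadable from compound 3 to compound 4 is estimated to be small, not beyond the usual scatter. Compound 4 is estimated at 110000 nM, in a range from 40000 nM to 300000 nM, with a sizeable chance that only a limit is reported.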

Compound 4, half-maximal inhibitory concentration: > 100000 nM
Compound 4 was reported as a limit (the forecaster's own chance of this, stated with the estimate: 65%); the middle value does not contradict the limit.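

In this assay compound 4 gives > 100000 nM, which is a limit and not a number. Among the compounds shown here, compound 3 also stands at a limit, so no step between compound 3 and compound 4 can be read. The compounds shown leave open what size, if any, the change from methoxymethyl to methyl has in this assay.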